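Ethyl in Place of Nitro: Expected Cytotoxicity of Compound 4

The compounds below may be only part of what the source reports. "The series", "measured", "known", "first", "only" and "open" are said of these compounds alone.

Of the compounds shown here, three built on one shared core have been tested in an ADME assay on PC-3 cells (Homo sapiens) for cytotoxicity, read by WST assay, tested at 100 uM; on this read-out higher numbers stand for more inhibition at the one concentration tested (going by the name of the read-out) and lower numbers for less inhibition. Compound 1 `O=C(Nc1cccc(Oc2ccccn2)c1)C1CCCN(C(=O)c2cc(C(F)(F)F)cc(C(F)(F)F)c2)C1` gives 0%. Compound 2 `CC(C)(C)OC(=O)c1cccc(NC(=O)C2CCCN(C(=O)c3cc(C(F)(F)F)cc(C(F)(F)F)c3)C2)c1` gives 0%. Compound 3 `O=C(Nc1cccc([N+](=O)[O-])c1)C1CCCN(C(=O)c2cc(C(F)(F)F)cc(C(F)(F)F)c2)C1` gives 9%. Compound 3 holds the highest of the three numbers, yet its steps to both others lie within the scatter: a number 9 percentage points higher from compound 1 to compound 3 (within the scatter) and a number 9 percentage points higher from compound 2 to compound 3 (within the scatter). The remaining step, no change at the digits printed from compound 1 to compound 2 (within the scatter), is likewise flat, so the three numbers are level with one another within the scatter.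

Compound 4 `CCc1cccc(NC(=O)C2CCCN(C(=O)c3cc(C(F)(F)F)cc(C(F)(F)F)c3)C2)c1` differs from compound 3 in a single place: ethyl in place of nitro on an aromatic carbon. Among the measured compounds shown here, no measured step involves an ethyl group, but all three measured steps exchanged the group on an aromatic carbon of the same ring and each stayed within the scatter. Compound 4 is therefore expected to remain in the same low band, and a number 6 percentage points lower from compound 3 to compound 4 (within the scatter) is estimated to be at most a small downward movement, none beyond the scatter. The estimate for compound 4 is 3%, expected between 0% and 15%.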

Compound 4, a percentage reported as inhibition, at one concentration (the size of the read-out at that concentration, not a potency): 0%
Compound 4: middle estimate off by 3 percentage points, on the high side; the range from low to high includes it.
By their numbers in this assay, from the lowest: compounds 1, 2, 4 and 3 (each within the scatter of the next).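

With ethyl on this aromatic carbon, the group that enters has no nitrogen, oxygen or hydrogen-bond acceptor, unlike the nitro, (pyridin-2-yl)oxy and tert-butoxycarbonyl groups, yet this assay shows a number 9 percentage points lower from compound 3 to compound 4 (within the scatter). Against the other two groups the picture is equally flat, with no change at the digits printed from compound 2 to compound 4 (within the scatter) and no change at the digits printed from compound 1 to compound 4 (within the scatter), so a group of carbon and hydrogen alone joins the three heteroatom-bearing groups at this position, and all four compounds stand level within the scatter. No measurement is available that bears on why the numbers stay level here.

Going by these compounds, whether an amine or a carboxylic acid on this aromatic carbon, or a chain longer than ethyl, would move the number beyond the scatter remains open. The compounds shown also leave open whether any change to the rest of the shared core would do so.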